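Series notes: benzoyl to acetyl, compound 3 to compound 4

The source may hold more compounds than are shown below. What is called first, only, known or untested is meant among the compounds shown, and "the series" means these compounds.

Of the compounds shown here, three have so far been measured in an ADME assay on isolated protein for metabolic stability, with Cocaine esterase (Homo sapiens) as the target; a lower number here means that the compound disappears faster, a higher number that the compound lasts longer. Compound 1 `CCOC(=O)[C@@H](N)CCC(=O)NCCSC(C)=O` gives 0.167 h. Compound 2 `CCCCOC(=O)[C@@H](N)CCC(=O)NCCSC(=O)c1ccccc1` gives 0.167 h, and compound 3 `CCCOC(=O)[C@@H](N)CCC(=O)NCCSC(=O)c1ccccc1` gives 0.167 h. Compound 3 thus stands level with compound 1 and compound 2, all three at the same figure. Within the data shown here, the one single-change step measured, no change at the digits printed from compound 2 to compound 3 (within the scatter), shows nothing beyond the scatter.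

Compound 4 `CCCOC(=O)[C@@H](N)CCC(=O)NCCSC(C)=O` remains to be measured. Its change from compound 3: methyl in place of phenyl on a carbonyl carbon. Among the measured compounds shown here, no measured step covers this change directly, so only values can be set side by side. Compound 1 carries the acetyl and gives 0.167 h. Compound 2 carries the benzoyl and gives 0.167 h; compound 3 carries the benzoyl and gives 0.167 h. No gap beyond the scatter is visible between these three.

For compound 4 no step beyond the scatter is therefore expected in this assay, the estimated step being no change at the digits printed from compound 3 to compound 4 (within the scatter). Compound 4 is expected to give 0.167 h, within a range of 0.08 h to 0.35 h.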

Compound 4, half-life: 0.167 h
The estimate for compound 4 equals the measured number at the digits printed; the measured number falls inside the stated range.
By their numbers in this assay, from the lowest: compounds 1, 2, 3 and 4 (each within the scatter of the next).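

In this assay, among these compounds, methyl in place of phenyl on a carbonyl carbon whose other neighbour is sulfur now has a direct reading, which the earlier compounds could offer only as values set side by side: no change at the digits printed from compound 3 to compound 4 (within the scatter). With the acetyl in place, methyl in place of hydrogen on a saturated chain carbon, two bonds along the chain from an oxygen next to a carbonyl group, also gives no change at the digits printed from compound 1 to compound 4 (within the scatter). The chain change therefore has a reading with the acetyl as well as with the benzoyl, and the two agree: the same change on two cores in this assay, no change at the digits printed (within the scatter) from compound 2 to compound 3 and no change at the digits printed (within the scatter) from compound 4 to compound 1, 1.0-fold (0.00 log units) apart, within the scatter of two such steps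

All four compounds share one figure, so neither place has yet shown a step beyond the scatter. Open, going by these compounds, is whether a branched chain such as isopropyl on that oxygen, or a carboxylic acid in place of the whole ester, would separate from this level.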